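Sulfone aryl swap on a quinoline scaffold: cyanophenyl for dichlorophenyl

The source may report more compounds than this note shows. Statements on the series, on what has been measured and on what is new or still open speak of the compounds shown alone.

Measured compounds:
compound 1, `CC1CCN(c2c(S(=O)(=O)c3cc(Cl)cc(Cl)c3)cnc3ccc(Cl)cc23)CC1`, 88%
compound 2, `Cc1ccc(S(=O)(=O)c2cnc3c(F)cccc3c2N2CCC(C)CC2)cc1`, 93%
compound 3, `CC1CCN(c2c(S(=O)(=O)c3ccc(Cl)c(Cl)c3)cnc3cc(F)ccc23)CC1`, 94%

In an assay on isolated protein for displacement of a labelled ligand from metabotropic glutamate receptor 5 (Homo sapiens), with a stated time of 60 min, tested at 1 uM (a higher number here means more inhibition at the concentration tested (going by the name of the read-out), a lower number less inhibition), compound 3 gives 94%. The three numbers sit close together: the values of compound 2 and compound 1 differ from that of compound 3 by no more than the usual scatter, so no order among them can be claimed. Compound 4, `CC1CCN(c2c(S(=O)(=O)c3ccc(C#N)cc3)cnc3cc(F)ccc23)CC1`, has not been measured. It differs from compound 3 by 4-cyanophenyl in place of 3,4-dichlorophenyl on a sulfonyl sulfur. Among the compounds with values here, no step between measured compounds shows this change directly. From the compounds shown here alone, the aryl groups seen so far all carry halogen or methyl, and all give high inhibition; a nitrile is untested. A modest drop is expected, a number 10 percentage points lower from compound 3 to compound 4 (within the scatter), possibly within the scatter. Compound 4 is therefore estimated at 84%, between 60% and 97%.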

Compound 4, a percentage reported as inhibition, at one concentration (the size of the read-out at that concentration, not a potency): 83%
Estimate against measurement, compound 4: 1 percentage points above; low and high end bracket the measured number.
By their numbers in this assay, from the lowest: compounds 4, 1, 2 and 3 (each within the scatter of the next, the first and the last beyond it).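

In this assay, 4-cyanophenyl in place of 3,4-dichlorophenyl on a sulfonyl sulfur gives a number 11 percentage points lower from compound 3 to compound 4 (beyond the scatter), the first step shown at this position and the first with a nitrile on the aryl group. The position accepts a nitrile, as compound 4 still gives 83% in this read-out, but the swap is not silent. No measurement shown accounts for the step. The compounds shown do not separate losing the two chlorines from gaining the nitrile. From the compounds shown here alone, how an amine or a carboxylic acid on this aryl ring would read also remains open.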